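This account rests on a few compounds, and the source may have more. Where it says the series, first, only, none or still open, it means among the compounds named here.

In a functional assay on A549 cells (Homo sapiens) for antiproliferative activity, read by MTT assay (a higher number here means a weaker inhibitor, a lower number a stronger inhibitor), compound 1 `CC1(C)CCc2cc(C(=O)/C=C/c3ccc(OCc4cn(-c5ccc(Cl)cc5)nn4)cc3)c(O)cc2O1` gives 75500 nM and compound 2 `CCc1ccccc1-n1cc(COc2ccc(/C=C/C(=O)c3cc4c(cc3O)OC(C)(C)CC4)cc2)nn1` gives 137000 nM, two values that lie within the scatter of each other. Compound 3 `Cc1ccc(-n2cc(COc3ccc(/C=C/C(=O)c4cc5c(cc4O)OC(C)(C)CC5)cc3)nn2)cc1Br` carries 3-bromo-4-methylphenyl in place of 2-ethylphenyl on an aromatic nitrogen. Going by the values given here, the only measured step that bears on this, a 1.8-fold higher number from compound 1 to compound 2 (0.26 log units; within the scatter), also exchanges the group on that nitrogen and stays within the scatter, so no step beyond the scatter is expected in this assay. The expected size of the change is a 1.3-fold lower number from compound 2 to compound 3 (0.12 log units; within the scatter). The estimate for compound 3 is 105000 nM, with an expected range from 45000 nM to 220000 nM.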

Compound 3, half-maximal inhibitory concentration: 125000 nM
Compound 3: middle estimate off by 1.2-fold (0.08 log units), on the low side, within the range that was stated.
By their numbers in this assay, from the lowest: compounds 1, 3 and 2 (each within the scatter of the next).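

On the aromatic nitrogen, 3-bromo-4-methylphenyl now stands with 2-ethylphenyl and 4-chlorophenyl, and this assay shows a 1.1-fold lower number from compound 2 to compound 3 (0.04 log units; within the scatter) and a 1.7-fold higher number from compound 1 to compound 3 (0.22 log units; within the scatter) on the shared core. All three groups thus lie within the scatter of each other, and a third ring pattern at this position, now carrying bromine, leaves the numbers as close as the first two were. Nothing measured here offers an explanation for this result. Still open, on these data alone, is whether an amine, a carboxylic acid or a pyridine ring on that nitrogen would give a step beyond the scatter.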